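Benzyl on the Ring Amine: Expected Shift in Lipophilicity

The source may report more compounds than this note shows. Statements on the series, on what has been measured and on what is new or still open speak of the compounds shown alone.

Of the compounds shown here, three sharing one core have been measured in a physicochemical assay for lipophilicity; a lower number here means a more polar compound, a higher number a more lipophilic compound. Compound 1 `COCCNC(=O)C[C@H](NC(=O)c1ccc(C#Cc2ccccc2)cc1)C(=O)NO` gives 2. Compound 3 `O=C(NC1(C(=O)NO)CCNCC1)c1ccc(C#Cc2ccccc2)cc1` gives 3, the higher of the two numbers, a gap from compound 1 that lies beyond the scatter. Compound 2 `CC(NC(=O)c1ccc(C#Cc2ccccc2)cc1)C(=O)NO` reaches only a limit of the assay, > 3, which is a boundary rather than a number, (the limit of > 3 in this assay, at which 1 of the 3 values shown sits).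

Compound 4 `O=C(NC1(C(=O)NO)CCN(Cc2ccccc2)CC1)c1ccc(C#Cc2ccccc2)cc1` is not yet measured. It differs from compound 3 in one place: benzyl in place of hydrogen on an amine nitrogen in a ring. Among the measured compounds shown here, no step between measured compounds shows this kind of change, so there is no direct precedent. The expected step in this assay is a number 1.00 log units higher from compound 3 to compound 4 (beyond the scatter), an increase beyond the scatter. Compound 4 is expected to give 4, within a range from 3.3 to 4.8. It may be reported only as a limit.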

Compound 4, distribution coefficient: > 3
Compound 4: a limit, no number (the forecaster's own chance of this, stated with the estimate: 70%); the middle value is on the limit's open side.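

Benzyl in place of hydrogen on an amine nitrogen in a ring is the first change at this position to be seen in this assay, and the step (a number no lower from compound 3 to compound 4 (the limit leaves the size open)) shows only that the value does not fall; its size cannot be read. Compound 4 is a limit and not a number, and the limit now holds more of the compounds shown: the limit of > 3 in this assay, at which 2 of the 4 values shown sit.

Going by these compounds, whether a smaller group on this nitrogen, such as methyl, or a benzyl bearing a carboxylic acid would give a readable number remains open.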